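Cyano in place of sulfamoyl in compound 1

This account rests on a few compounds, and the source may have more. Where it says the series, first, only, none or still open, it means among the compounds named here.

Going by the values given here, compound 1 (`Cc1cc(Nc2cc(N3CCN(C)CC3)nc(Nc3ccc(S(N)(=O)=O)cc3)n2)n[nH]1`) gives 24000 nM in a functional assay on NCI-N87 cells (Homo sapiens) for antiproliferative activity, read by CCK-8 assay, with a stated time of 72 h (a lower number here means a stronger inhibitor, a higher number a weaker inhibitor), the higher of the two numbers measured so far. Compound 2 (`COc1cccc(Nc2nc(Nc3cc(C)[nH]n3)cc(N3CCN(C)CC3)n2)c1`) gives 7190 nM in this assay. Compound 3 (`Cc1cc(Nc2cc(N3CCN(C)CC3)nc(Nc3ccc(C#N)cc3)n2)n[nH]1`) has not yet been measured. It keeps the core of compound 1 and differs in one group: cyano in place of sulfamoyl on an aromatic carbon.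

Among the compounds with values here, only one measured step bears on this change: a 3.3-fold lower number from compound 1 to compound 2 (0.52 log units; beyond the scatter). That step also removes the 4-sulfamoylphenyl group and is modest, though beyond the scatter. It brings in 3-methoxyphenyl rather than 4-cyanophenyl, so it is only a rough guide. A modest step toward a lower number is expected in this assay, of similar or smaller size, and a result within the scatter of compound 1 would not be surprising.

For compound 3 the estimated value is 11000 nM, with an expected range of 4000 nM to 30000 nM. The expected change is a 2.2-fold lower number from compound 1 to compound 3 (0.34 log units; beyond the scatter).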

Compound 3, half-maximal inhibitory concentration: 5780 nM
Compound 3: middle estimate off by 1.9-fold (0.28 log units), on the high side, and the stated range covers the measured number.
By their numbers in this assay, from the lowest: compounds 3 and 2 (each within the scatter of the next); then compound 1.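

In this assay, exchanging sulfamoyl for cyano on the aromatic carbon para to a large group, with the core of compound 1 otherwise unchanged, gives a 4.2-fold lower number from compound 1 to compound 3 (0.62 log units; beyond the scatter) and shows that the number responds to the group at this position alone. Two different replacements for 4-sulfamoylphenyl now give values that cannot be told apart, with a 1.2-fold lower number from compound 2 to compound 3 (0.09 log units; within the scatter), while the steps from compound 1 to each of them lie beyond the scatter, so within this small set compound 1 stands apart and 4-cyanophenyl and 3-methoxyphenyl do not separate. No measurement at hand accounts for the gain on leaving sulfamoyl, and the reason for it stays unknown.

From the compounds shown here alone, whether a carboxylic acid, a primary amide or a chlorine at the same position would fall with compound 3 or with compound 1 remains open. Also open, going by these compounds, is whether the step from sulfamoyl to cyano keeps its size when another part of the shared core changes, since these compounds test it on one core only.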